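The source may hold more compounds than are shown below. What is called first, only, known or untested is meant among the compounds shown, and "the series" means these compounds.

Working notes on the series. Among the compounds with values here, compound 1 `[O-][S+](CCC(F)(Cl)C(F)(F)Cl)c1nc2ccc(Cl)cc2s1` gives in a functional assay on MCF7 cells (Homo sapiens) for cytotoxicity, read by MTT assay, with a stated time of 48 h (a lower number here means a stronger inhibitor, a higher number a weaker inhibitor), a value of 12200 nM, the only plain number in hand. Compound 2 `O=S(=O)(CCC(F)=C(F)F)c1ccccn1` returns in this assay only a limit, > 120000 nM. One line of the record is the limit of > 120000 nM in this assay, at which 1 of the 2 values shown sits. Compound 3 `[O-][S+](CCC(F)(Cl)C(F)(F)Cl)c1nc2ccccc2s1` is not yet measured; it differs from compound 1 by hydrogen in place of chloro on an aromatic carbon. Within the data shown here, no measured step of this kind exists in the set, so the expected step of a 1.5-fold higher number from compound 1 to compound 3 (0.17 log units; within the scatter) is small, leaning toward a slightly weaker inhibitor, and may not exceed the scatter. For compound 3 the estimate is 18000 nM, within 6000 nM to 50000 nM.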

Compound 3, half-maximal inhibitory concentration: 17100 nM
For compound 3 the middle estimate is 1.1-fold (0.02 log units) above the measured one; the measured number falls inside the stated range.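

In this assay, within the data shown here, the step of a 1.4-fold higher number from compound 1 to compound 3 (0.15 log units; within the scatter) is the first measured change at this position. Hydrogen in place of chloro on this aromatic carbon therefore does not separate compound 1 from compound 3, and the chloro is not required for the cytotoxicity read here. Nothing on record bears on this result.

On these data alone, whether an amine or a carboxylic acid on the same aromatic carbon would give a step beyond the scatter stays open. The compounds shown also give no measured step at any other position of the shared core or on its halogenated chain.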